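The source may hold more compounds than are shown below. What is called first, only, known or untested is meant among the compounds shown, and "the series" means these compounds.

Measured compounds:
compound 1, `COc1ccccc1N1CCN(C(=O)CCc2c(-c3ccc(Cl)cc3)[nH]c3c(Cl)cc(Cl)cc23)CC1`, 14 nM
compound 2, `Cn1c(-c2ccc(Cl)cc2)c(CCC(=O)N2CCC(O)(Cc3ccccc3)CC2)c2cc(Cl)ccc21`, 0.16 nM

Both compounds were tested in an assay on CHO cells for displacement of a labelled ligand from Substance-P receptor (Homo sapiens); a higher number here means a weaker inhibitor, a lower number a stronger inhibitor. Compound 1 gives 14 nM, and compound 2 gives 0.16 nM. Of these two numbers, compound 2 has the lower one, and its gap to compound 1 lies beyond the scatter of repeated measurements.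

Compound 3 `Cn1c(-c2ccc(Cl)cc2)c(CCC(=O)N2CCC(O)(Cc3ccccc3)CC2)c2cc(-c3ccncc3)ccc21` has not yet been measured. It differs from compound 2 in one place: pyridin-4-yl in place of chloro on an aromatic carbon. No pair of measured compounds isolates this change, so nothing in the data shown tells its size. The expected step is a 3.1-fold higher number from compound 2 to compound 3 (0.49 log units; beyond the scatter), a modest move toward a higher number that may well fall within the usual scatter. For compound 3 in this assay the estimate is 0.5 nM, with a range from 0.1 nM to 3 nM.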

Compound 3, half-maximal inhibitory concentration: 5.5 nM
The estimate for compound 3 lay 11-fold (1.04 log units) below the measured number, outside the stated range (above it).
By their numbers in this assay, from the lowest: compound 2; then compound 3; then compound 1.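

Replacing chloro with pyridin-4-yl on this aromatic carbon gives a 34-fold higher number from compound 2 to compound 3 (1.54 log units; beyond the scatter) in this assay, a large step that shows binding here depends strongly on which group the position carries. Even so, the position tolerates the added aromatic ring to a measurable degree: compound 3 still gives 5.5 nM. Nothing available accounts for the size of this step.

The compounds shown leave open whether the step follows from the ring itself or from its nitrogen, a question that phenyl or pyridin-3-yl at the same carbon would address. They also leave open how smaller replacements for chloro, such as fluoro, methoxy or an amine, would behave, and so whether the response to size at this position is gradual or abrupt.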